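A few compounds are considered here, and "the series" means these few. Any claim that something is new, unique, unknown or untested is made for them only; others in the source may bear on it.

Measured so far:
Compound 1: `COc1ccc(C2CC(C3C(=O)c4ccccc4C3=O)=NC(=O)N2)cc1`, with 22% in a functional assay on the whole organism for inhibition, with Rattus norvegicus as the target, read by paw edema, with stated times of 30 min and 3 h, at a dose of 10 mg/kg by the oral route; a lower number here means less inhibition, a higher number more inhibition at the dose given (going by the name of the read-out)
Compound 2: `O=C1N=C(C2C(=O)c3ccccc3C2=O)CC(c2cccc([N+](=O)[O-])c2)N1`, with 21% in this assay

Compound 1 holds the higher of the two numbers, yet the step of a number 1 percentage points lower from compound 1 to compound 2 (within the scatter) lies within the scatter, so the two compounds cannot be told apart on this read-out. Compound 3 is `O=C1N=C(C2C(=O)c3ccccc3C2=O)CC(c2ccco2)N1`; it differs from compound 1 by furan-2-yl in place of 4-methoxyphenyl on a saturated ring carbon. Within the data shown here, the one measured step that bears on this change is the one from compound 1 to compound 2, where a different six-membered aromatic ring was put on the same saturated ring carbon and the read-out moved by a number 1 percentage points lower from compound 1 to compound 2 (within the scatter). Among the measured compounds shown here, that step only shows that one aromatic ring for another at this carbon left the number where it was; a five-membered furan-2-yl at this carbon has no measured counterpart. For the measured compounds named here, with that single, flat step as the only guide, the change to compound 3 is expected to give a step of a number 2 percentage points lower from compound 1 to compound 3 (within the scatter), none beyond the scatter. Compound 3 is therefore estimated at 20%, with a range from 8% to 32%.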

Compound 3, a percentage reported as inhibition, in the whole organism at one dose (the size of the read-out at that dose, not a potency): 20%
Estimate against measurement, compound 3: no gap at the digits printed, within the range that was stated.
By their numbers in this assay, from the lowest: compounds 3, 2 and 1 (each within the scatter of the next).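

In this assay, putting the five-membered furan-2-yl on this saturated ring carbon gives a number 2 percentage points lower from compound 1 to compound 3 (within the scatter), and the comparison with the nitro-bearing ring gives a number 1 percentage points lower from compound 2 to compound 3 (within the scatter). The flat picture therefore no longer rests on two six-membered rings of carbon alone: it now includes a five-membered aromatic ring with a hetero atom, and the three compounds cannot be told apart on this read-out. Nothing further is available to explain why exchanging these aromatic rings at this carbon makes no difference that can be detected here.

On these data alone, all three groups at this position are aromatic rings, so it remains open whether a group without such a ring, such as a cyclohexyl ring, a methyl group or a short chain ending in an amine, would give a number in the same range. The shared core also stays the same throughout, and a read-out at a single dose is not a potency, so these compounds cannot show how the effect would change with dose or with a change elsewhere in the core.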